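Notes on adding a third methoxy group to compound 3

This account rests on a few compounds, and the source may have more. Where it says the series, first, only, none or still open, it means among the compounds named here.

Compound 3 `COc1cc(Nc2nc3ccccc3nc2S(=O)(=O)c2ccccc2)cc(OC)c1` gives 950 nM in a functional assay on HCT-116 cells (Homo sapiens) for cytotoxicity, read by MTT assay, with a stated time of 72 h (on this read-out lower numbers stand for stronger inhibition and higher numbers for weaker inhibition), the lowest of the three numbers recorded, though a 1.7-fold lower number from compound 1 to compound 3 (0.23 log units; within the scatter) stays within the scatter; compound 1 `O=S(=O)(c1ccccc1)c1nc2ccccc2nc1Nc1ccccc1` gives 1630 nM and compound 2 `COc1ccc(Nc2nc3ccccc3nc2S(=O)(=O)c2ccccc2)cc1` gives 2420 nM. Compound 4 `COc1cc(Nc2nc3ccccc3nc2S(=O)(=O)c2ccccc2)cc(OC)c1OC` differs from compound 3 by methoxy in place of hydrogen on an aromatic carbon. Going by the values given here, the only step of the same kind is a 1.5-fold higher number from compound 1 to compound 2 (0.17 log units; within the scatter). The step of a 2.5-fold lower number from compound 2 to compound 3 (0.41 log units; beyond the scatter) moves methoxy groups rather than adding one and bears on it only loosely. On this basis no step beyond the scatter is expected in this assay, with at most a slight lean toward a higher number. Compound 4 is therefore expected at 1200 nM, in the range 500 nM to 2900 nM, an expected step of a 1.3-fold higher number from compound 3 to compound 4 (0.10 log units; within the scatter).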

Compound 4, half-maximal inhibitory concentration: > 50000 nM
Compound 4 ended at the assay's limit; the forecaster's own chance of this, stated with the estimate: 3%; middle value at least 41-fold (1.61 log units) away from the limit.
By their numbers in this assay, from the lowest: compounds 3, 1 and 2 (each within the scatter of the next, the first and the last beyond it). At a limit, above all of these: compound 4.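

In this assay, methoxy in place of hydrogen at the carbon ortho to two methoxy groups and para to a large group gives an at least 52-fold higher number from compound 3 to compound 4 (1.72 log units; beyond the scatter). The value of compound 4, > 50000 nM, is a limit of the assay and not a number. This change therefore depends strongly on the methoxy groups already present: the same change on two cores in this assay, a 1.5-fold higher number (0.17 log units; within the scatter) from compound 1 to compound 2 and an at least 52-fold higher number (1.72 log units; beyond the scatter) from compound 3 to compound 4, at least 35-fold (1.54 log units) apart, beyond the scatter of two such steps

The compounds shown leave open how far the result is specific to methoxy. A fluorine, a hydroxyl or an amine at this carbon, with both other methoxy groups kept, would test this.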